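Removing the chloro from compound 2: an expected inactive analogue

A few compounds are considered here, and "the series" means these few. Any claim that something is new, unique, unknown or untested is made for them only; others in the source may bear on it.

Compound 1, `COc1ccc(OC)c(/C=C/c2nnc(Nc3ccc(Cl)cc3)o2)c1`, in a functional assay on SK-MEL-2 cells (Homo sapiens) for antiproliferative activity, read by sulforhodamine B assay, with a stated time of 48 h (a lower number here means a stronger inhibitor of growth, a higher number a weaker inhibitor of growth), gives > 100000 nM, which is a limit of the assay.
Compound 2, `COc1ccc(OC)c(/C=C/C(=O)N/N=C/c2ccc(Cl)cc2)c1`, in this assay gives > 100000 nM, which is again a limit of the assay.

Neither measured compound gives a number in this assay. Compound 2 therefore stands at the limit, and the other value shown stands at the same limit, as the limit of > 100000 nM in this assay, at which 2 of the 2 values shown sit, records. Going by the values given here, no step between measured compounds can be drawn from this, since both values are limits rather than numbers.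

Compound 3, `COc1ccc(OC)c(/C=C/C(=O)N/N=C/c2ccccc2)c1`, differs from compound 2 only in hydrogen in place of chloro on an aromatic carbon. Among the compounds with values here, with the only comparable value being a limit, there is no measured change on which to base a direction for this change, and the expectation is that compound 3 behaves like compound 2 in this assay, with no step beyond the scatter. The step from compound 2 to compound 3 is estimated as a step that the limit leaves unreadable from compound 2 to compound 3. For compound 3 the estimated value in this assay is 150000 nM, with a range from 50000 nM to 500000 nM, and most likely the assay again reports only a limit.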

Compound 3, concentration for total growth inhibition: 9320 nM
Estimate against measurement, compound 3: 16-fold (1.21 log units) above; the whole stated range lies above it.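

Hydrogen in place of chloro on an aromatic carbon, para to a large group, brings an at least 10-fold lower number from compound 2 to compound 3 (1.03 log units; beyond the scatter), and with it compound 3 gives the only actual number among the compounds shown in this assay. The earlier compounds shown here could show only that activity lay out of reach of the assay, whereas this pair shows that the position is sensitive and that, on this core, chloro is not required for growth inhibition; in this one pair, phenyl goes with the stronger inhibitor and 4-chlorophenyl with the weaker one. The true size of the step remains unknown, as only its lower bound can be read, since one of its two ends is a limit and not a number: the limit of > 100000 nM in this assay, at which 2 of the 3 values shown sit.

As far as these compounds go, whether a different group at this position, such as fluoro, methoxy or an amine, would hold, raise or lose this activity stays open, as a single pair cannot separate an effect of chloro in particular from one of any substituent there. Also open, from the compounds shown here alone, is whether the same change, 4-chlorophenyl to phenyl, would have a similar effect on the core of compound 1.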